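Aryl ether series: from compound 1 to compound 4

A few compounds are considered here, and "the series" means these few. Any claim that something is new, unique, unknown or untested is made for them only; others in the source may bear on it.

Measured in a functional assay on CRL2813 cells (Homo sapiens) for cytotoxicity, read by sulforhodamine B assay, with a stated time of 5 days; on this read-out higher numbers stand for weaker inhibition and lower numbers for stronger inhibition:
compound 1, `O=C(Nc1cccc(C(F)(F)F)c1)N[C@H]1CC[C@H](Oc2cccc(F)c2)CC1`: 2400 nM
compound 2, `O=C(Nc1ccc(I)cc1)N[C@H]1CC[C@H](Oc2ccc(F)cc2)CC1`: 10200 nM
compound 3, `O=C(Nc1cccc(Br)c1)N[C@H]1CC[C@H](Oc2ccc(F)cc2)CC1`: 6200 nM

Compound 1 shows the lowest number of the three, beyond the scatter from both compound 3 and compound 2. Going by the values given here, the only single-site step measured, a 1.6-fold lower number from compound 2 to compound 3 (0.22 log units; within the scatter), concerns the group on the amide-type nitrogen and stays within the scatter, so it gives no guidance on the ether side. Compound 4, `O=C(Nc1cccc(C(F)(F)F)c1)N[C@H]1CC[C@H](Oc2cccc(C(F)(F)F)c2)CC1`, differs from compound 1 at the ether ring: trifluoromethyl in place of fluoro on an aromatic carbon. Among the compounds with values here, no measured pair shows this change, and no step bears on it. Without such a reference, the expectation in this assay is a step of no more than the scatter in either direction. Compound 4 is therefore estimated at 2000 nM, in the range 700 nM to 6000 nM, meaning an expected step of a 1.2-fold lower number from compound 1 to compound 4 (0.08 log units; within the scatter).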

Compound 4, half-maximal inhibitory concentration: 1300 nM
Beside the measured number, compound 4's estimate is 1.5-fold (0.19 log units) above it, within the range that was stated.
By their numbers in this assay, from the lowest: compounds 4 and 1 (each within the scatter of the next); then compounds 3 and 2 (each within the scatter of the next).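

On the ether ring, with 3-(trifluoromethyl)phenyl in place of 3-fluorophenyl, this assay gives a 1.8-fold lower number from compound 1 to compound 4 (0.27 log units; within the scatter), so four heavy atoms in place of one leave the number within the scatter. Going by these compounds alone, this is the first single-site step on the ether side; the earlier step concerned the amide-type nitrogen. Nothing available accounts for the result.

From the compounds shown here alone, whether an amine, a carboxylic acid or a longer chain at this position would keep the number within the scatter stays open. So does whether this change reads the same with 3-bromophenyl on the amide-type nitrogen.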